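Ethoxy to propoxy: one further chain step

A few compounds are considered here, and "the series" means these few. Any claim that something is new, unique, unknown or untested is made for them only; others in the source may bear on it.

Measured values in a functional assay on ZR-75-1 cells (Homo sapiens) for cytotoxicity, read by MTT assay, with a stated time of 72 h (on this read-out lower numbers stand for an effect already at smaller amounts and higher numbers for an effect only at larger amounts of compound), so far:
- compound 1 `CCc1cccc2c(OC)c(-c3occ(C)c3C(=O)OC)ccc12` at 1.3 ug/mL
- compound 2 `CCOC(=O)c1c(C)coc1-c1ccc2c(CC)cccc2c1OC` at 3.9 ug/mL

Compound 2 stands at 3.9 ug/mL as the higher of the two numbers, with compound 1 as its nearest neighbour. The change to the unmeasured compound 3 `CCCOC(=O)c1c(C)coc1-c1ccc2c(CC)cccc2c1OC` is methyl in place of hydrogen on a saturated chain carbon, two bonds along the chain from an oxygen next to a carbonyl group and reads methyl in place of hydrogen on a saturated chain carbon, two bonds along the chain from an oxygen next to a carbonyl group, or ethoxy to propoxy. Among the measured compounds shown here, only one measured step bears on it, methyl in place of hydrogen on a saturated chain carbon bound to an oxygen next to a carbonyl group, which gave a 3.0-fold higher number from compound 1 to compound 2 (0.48 log units; beyond the scatter) and so a further rise of like or smaller size is expected in this assay with no change beyond the scatter still possible. The expected step, an estimate from that single precedent, is a 1.5-fold higher number from compound 2 to compound 3 (0.19 log units; within the scatter) for now. Compound 3 is estimated at 6 ug/mL with an expected range from 2.5 ug/mL to 13 ug/mL on this read-out.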

Compound 3, concentration for half-maximal effect: > 10 ug/mL
Compound 3 gave a limit, no number; the forecaster's own chance of this, stated with the estimate: 3%; at least 1.6-fold (0.22 log units) between middle value and limit.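

In this assay the rise seen at the first chain step continues: ethoxy to propoxy gives an at least 2.5-fold higher number from compound 2 to compound 3 (0.40 log units; beyond the scatter), a bound set by a limit and not a measured size. Taken together, the chain steps give an at least 7.6-fold higher number from compound 1 to compound 3 (0.88 log units; beyond the scatter), also only a bound. Across compounds 1, 2 and 3, the number rises as the chain grows, with no compound going against this, but how far compound 3 lies beyond the limit cannot be read: the limit of > 10 ug/mL in this assay, at which 1 of the 3 values shown sits.

The compounds shown leave open whether chain length alone governs this rise, a question that an isopropyl ester, a carboxylic acid or an amide in place of the ester would test. Going by these compounds, whether the same order holds in other cell lines also stays open.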